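From sec-butyl to 2-ethoxyethyl on a shared core

A few compounds are considered here, and "the series" means these few. Any claim that something is new, unique, unknown or untested is made for them only; others in the source may bear on it.

Measured in a functional assay (Nicotiana tabacum); on this read-out lower numbers stand for stronger inhibition and higher numbers for weaker inhibition:
- Compound 1 `CCCCNc1nc(SC)nc2ncccc12`: 270 nM
- Compound 2 `CCCCCNc1nc(SC)nc2ncccc12`: 650 nM
- Compound 3 `CCC(C)Nc1nc(SC)nc2ncccc12`: 860 nM

Compound 3 sits close to one neighbour and further from the other: a 1.3-fold higher number from compound 2 to compound 3 (0.12 log units; within the scatter), but a 3.2-fold higher number from compound 1 to compound 3 (0.50 log units; beyond the scatter). Compound 4 `CCOCCNc1nc(SC)nc2ncccc12` carries 2-ethoxyethyl in place of sec-butyl on a nitrogen on an aromatic ring. Within the data shown here, no measured compound contains this group, so the guidance is only indirect. The nearest evidence is that changing the butyl chain of compound 1 gave modest steps: a 2.4-fold higher number from compound 1 to compound 2 (0.38 log units; beyond the scatter), and a 3.2-fold higher number from compound 1 to compound 3 (0.50 log units; beyond the scatter). In this assay, a small change that stays within the scatter is therefore expected: a 1.1-fold lower number from compound 3 to compound 4 (0.03 log units; within the scatter). For compound 4 the estimated value is 800 nM, with an expected range of 300 nM to 2200 nM.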

Compound 4, half-maximal inhibitory concentration: 7590 nM
Beside the measured number, compound 4's estimate is 9.5-fold (0.98 log units) below it, and the stated range ends below it.
By their numbers in this assay, from the lowest: compound 1; then compounds 2 and 3 (each within the scatter of the next); then compound 4.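

In this assay the move to 2-ethoxyethyl is a bigger change than any seen among the all-carbon chains (an 8.8-fold higher number from compound 3 to compound 4 (0.95 log units; beyond the scatter)), (a 12-fold higher number from compound 2 to compound 4 (1.07 log units; beyond the scatter)) and (a 28-fold higher number from compound 1 to compound 4 (1.45 log units; beyond the scatter)). At this nitrogen on an aromatic ring, swapping among butyl, pentyl and sec-butyl shifted the number far less than bringing in a chain that holds an oxygen. Nothing available explains this jump.

Open, on these data alone, is whether a 3-methoxypropyl chain, with the oxygen elsewhere, would behave the same way. As far as these compounds go, a propyl chain or a cyclopentyl ring is equally open.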